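Swapping the amine side chain of a cell-growth inhibitor

The source may report more compounds than this note shows. Statements on the series, on what has been measured and on what is new or still open speak of the compounds shown alone.

The compounds here share one core, shown in compound 1 `COc1cc(Oc2cccc(Nc3ccccc3)c2)cc(OC)c1CNCCNC(C)=O`, and differ only in what hangs from the amine nitrogen. Among the compounds with values here, in a functional assay on DLD-1 cells (Homo sapiens) for inhibition, read by MTT assay, with a stated time of 72 h (on this read-out higher numbers stand for weaker inhibition and lower numbers for stronger inhibition), compound 1 gives 6010 nM, the only plain number in the set. Compound 2 `CCN1CCN(Cc2c(OC)cc(Oc3cccc(Nc4ccccc4)c3)cc2OC)CC1` carries a 4-ethylpiperazin-1-yl group in place of the (2-acetamidoethyl)amino group, and in this assay compound 2 reaches only a limit, > 20000 nM, which is the edge of what the assay reports and not a measured number (the limit of > 20000 nM in this assay, at which 1 of the 2 values shown sits). That step, an at least 3.3-fold higher number from compound 1 to compound 2 (0.52 log units; beyond the scatter), shows that altering the group on this nitrogen can cost potency.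

Compound 3 `COc1cc(Oc2cccc(Nc3ccccc3)c2)cc(OC)c1CNC1CC1` is not yet measured. It changes the same position: cyclopropyl in place of 2-acetamidoethyl on an amine nitrogen. Within the data shown here, the single measured step in this region points toward weaker inhibition, though it involved a different group, so it bears only loosely on the new change. The estimate for compound 3 in this assay is therefore a modest loss, a 1.5-fold higher number from compound 1 to compound 3 (0.18 log units; within the scatter), with a value expected near 9000 nM within a range from 2500 nM to 30000 nM.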

Compound 3, half-maximal inhibitory concentration: > 20000 nM
Compound 3: a limit, no number; the forecaster's own chance of this, stated with the estimate: 30%; middle value at least 2.2-fold (0.34 log units) away from the limit.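

Putting cyclopropyl, a three-membered ring of carbon only, in place of 2-acetamidoethyl on this amine nitrogen gives an at least 3.3-fold higher number from compound 1 to compound 3 (0.52 log units; beyond the scatter), so the earlier loss in this assay was not peculiar to the 4-ethylpiperazin-1-yl group of compound 2. Compound 3 gives > 20000 nM, which is a limit of the assay and not a number. Among these compounds, only compound 1, with its 2-acetamidoethyl group, gives a plain number, while compound 2 and compound 3 both stop at the same limit, so the step between them cannot be read: the limit of > 20000 nM in this assay, at which 2 of the 3 values shown sit.

On these data alone, how far beyond the limit compound 2 and compound 3 lie remains unknown, so these two groups cannot be placed in order. As far as these compounds go, it also remains open which part of the 2-acetamidoethyl group goes with the measurable inhibition of compound 1, a question that a 2-aminoethyl group, ending in a free amine, or a longer chain ending in the same acetamide could help to answer.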